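This account rests on a few compounds, and the source may have more. Where it says the series, first, only, none or still open, it means among the compounds named here.

Of the compounds shown here, three of one shared core have been tested in a functional assay on CHO cells for agonist activity at Alpha-2C adrenergic receptor (Homo sapiens); on this read-out lower numbers stand for smaller maximal responses and higher numbers for larger maximal responses. Compound 1, `CSc1ccc(F)cc1NCC1=NCCN1`, gives 97%. Among the compounds with values here, compound 2, `COc1ccc(SC)c(NCC2=NCCN2)c1`, gives 74%, and the only single-point change among the measured compounds, a number 23 percentage points lower from compound 1 to compound 2 (beyond the scatter), shows a modest loss. Compound 3, `CS(=O)(=O)c1ccc(C(F)(F)F)cc1NCC1=NCCN1`, gives 25% in this assay, the lowest of the three numbers and well beyond the scatter below both others.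

Compound 4, `CSc1ccc(C(F)(F)F)cc1NCC1=NCCN1`, differs from compound 3 in one place: methylsulfanyl in place of methylsulfonyl on an aromatic carbon. Within the data shown here, no measured step touches this exchange, since the one step recorded, from compound 1 to compound 2, swaps a different group, so it gives no direct guide. What can be said is that compound 1 and compound 2, which both carry methylsulfanyl, reach large responses, whereas compound 3 with methylsulfonyl reaches a small one. Among the measured compounds shown here, on that basis a rise is expected, though the trifluoromethyl group kept in compound 4 appears in no high-responding compound, which widens the uncertainty. The expected step is a number 45 percentage points higher from compound 3 to compound 4 (beyond the scatter), and compound 4 is estimated at 70%, within a range from 45% to 95%.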

Compound 4, largest response reached (reported as maximum), in percent of the reference or control that the assay uses: 45%
Compound 4: the middle estimate sits 25 percentage points above what was measured; the measured number falls inside the stated range.
By their numbers in this assay, from the lowest: compound 3; then compound 4; then compound 2; then compound 1.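

In this assay, the exchange of methylsulfonyl for methylsulfanyl, on the aromatic carbon para to a trifluoromethyl group, now has a direct reading: a number 20 percentage points higher from compound 3 to compound 4 (beyond the scatter) shows that this single change raises the maximal response. Methylsulfanyl alone does not restore the largest responses, since trifluoromethyl in place of methoxy gives a number 29 percentage points lower from compound 2 to compound 4 (beyond the scatter) and trifluoromethyl in place of fluoro gives a number 52 percentage points lower from compound 1 to compound 4 (beyond the scatter) so the group in that second place also counts, with both changes leaving methylsulfanyl untouched. Nothing available explains these differences.

Still open, going by these compounds, is whether the same exchange would give a step of similar size with fluoro or methoxy kept in place of trifluoromethyl. Also open, on these data alone, is how an amine or a longer chain such as ethylsulfanyl would behave in place of methylsulfanyl.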